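The compounds below may be only part of what the source reports. "The series", "measured", "known", "first", "only" and "open" are said of these compounds alone.

Measured compounds:
compound 1 `C#CCn1cc(C(=O)NC(CC(=O)Nc2ccccc2)c2ccccc2)c(=O)c2cc(F)c(Cl)nc21`: 6600 nM
compound 2 `C#CCn1cc(C(=O)NC(CC(=O)NC2CCCCC2)c2ccccc2)c(=O)c2cc(F)c(Cl)nc21`: 6200 nM

In a functional assay on K562 cells (Homo sapiens) for cytotoxicity, read by MTT assay, with a stated time of 72 h (on this read-out lower numbers stand for stronger inhibition and higher numbers for weaker inhibition), compound 1 gives 6600 nM and compound 2 gives 6200 nM. Of these two numbers, that of compound 1 is the higher, but the step of a 1.1-fold lower number from compound 1 to compound 2 (0.03 log units; within the scatter) lies within the scatter, so the two compounds cannot be told apart on this read-out.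

Compound 3 `C#CCn1cc(C(=O)NC(CC(=O)Nc2ccccc2)c2ccccc2)c(=O)c2ccc(Cl)nc21` differs from compound 1 in a single place: hydrogen in place of fluoro on an aromatic carbon. Among the compounds with values here, no measured step speaks to this change. Within the data shown here, the only step available, from compound 1 to compound 2, alters the amide substituent on the side chain and leaves the fused core untouched, so it gives no guide to what the loss of the fluoro group does. The expectation for compound 3 therefore rests on compound 1 alone and is worded with a wide range: the step of a 1.2-fold higher number from compound 1 to compound 3 (0.08 log units; within the scatter) is expected to be small, with no clear direction beyond the scatter. On that basis compound 3 is estimated at 8000 nM in this assay, with a likely range from 3000 nM to 22000 nM.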

Compound 3, half-maximal inhibitory concentration: 7700 nM
The estimate for compound 3 lay 1.0-fold (0.02 log units) above the measured number; measured number inside the range.
By their numbers in this assay, from the lowest: compounds 2, 1 and 3 (each within the scatter of the next).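

In this assay, hydrogen in place of fluoro on the aromatic carbon ortho to the chloro group gives a 1.2-fold higher number from compound 1 to compound 3 (0.07 log units; within the scatter), so compound 1 and compound 3 cannot be told apart on this read-out. Within the data shown here, this is the first measured step on the shared core rather than on the side-chain amide, and it shows that, with the phenyl amide in place, cytotoxicity in these cells stays at the same level without the fluoro group. Nothing in the available data explains this result.

The compounds shown carry only fluoro or hydrogen on this carbon, so it stays open whether another group there, such as a methoxy group, an amine or a nitrile, would leave the number where it is or move it beyond the scatter. As far as these compounds go, it also stays open whether the same exchange would read alike on the cyclohexyl amide of compound 2, and what an amine in place of the chloro group would do to the cytotoxicity of the shared core.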